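From fluoro to iodo: what to expect of compound 4

The source may report more compounds than this note shows. Statements on the series, on what has been measured and on what is new or still open speak of the compounds shown alone.

Measured in a functional assay on NCI-H322 cells (Homo sapiens) for cytotoxicity, read by MTT assay, with a stated time of 24 h; a higher number here means a weaker inhibitor, a lower number a stronger inhibitor:
Compound 1 `COc1ccccc1-n1cc(COc2c(/C=C\C(=O)O)ccc(OC)c2CC=C(C)C)nn1`: 41500 nM
Compound 2 `COc1ccc(/C=C\C(=O)O)c(OCc2cn(-c3ccccc3F)nn2)c1CC=C(C)C`: 45600 nM
Compound 3 `COc1ccc(/C=C\C(=O)O)c(OCc2cn(-c3ccc(CO)cc3)nn2)c1CC=C(C)C`: 27100 nM

Compound 2 stands within the scatter of both other compounds, as a 1.1-fold higher number from compound 1 to compound 2 (0.04 log units; within the scatter) and a 1.7-fold lower number from compound 2 to compound 3 (0.23 log units; within the scatter) show. The remaining step, a 1.5-fold lower number from compound 1 to compound 3 (0.19 log units; within the scatter), is also within the scatter, so the three values cannot be told apart.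

Compound 4 `COc1ccc(/C=C\C(=O)O)c(OCc2cn(-c3ccccc3I)nn2)c1CC=C(C)C` has not yet been measured. It differs from compound 2 as follows: iodo in place of fluoro on an aromatic carbon. This places iodo in place of fluoro on an aromatic carbon, ortho to a large group.

Within the data shown here, no measured compound carries iodo, so the data hold no direct test of this change. The closest measured change, fluoro in place of methoxy on an aromatic carbon, is a 1.1-fold higher number from compound 1 to compound 2 (0.04 log units; within the scatter), and it stays within the scatter. No step beyond the scatter is therefore expected in this assay, and the estimated step is a 1.2-fold lower number from compound 2 to compound 4 (0.08 log units; within the scatter). For compound 4 the estimated value is 38000 nM, with an expected range from 19000 nM to 75000 nM.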

Compound 4, half-maximal inhibitory concentration: 42300 nM
Compound 4: the middle estimate sits 1.1-fold (0.05 log units) below what was measured; measured number inside the range.
By their numbers in this assay, from the lowest: compounds 3, 1, 4 and 2 (each within the scatter of the next).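

The iodo compound gives the first direct test of a heavier halogen on this aromatic carbon, ortho to a large group, and in this assay the exchange of fluoro for iodo is a small one (a 1.1-fold lower number from compound 2 to compound 4 (0.03 log units; within the scatter)), so the two halogens cannot be told apart here. Compound 4 also cannot be told apart from the compounds with other aryl groups on the aromatic nitrogen (a 1.0-fold higher number from compound 1 to compound 4 (0.01 log units; within the scatter); a 1.6-fold higher number from compound 3 to compound 4 (0.19 log units; within the scatter)), and all four compounds now lie within the scatter of one another. The data shown offer no explanation for this result.

As far as these compounds go, whether an amine or a nitrile on this aromatic carbon would give a step beyond the scatter remains open. From the compounds shown here alone, all four compounds share the core, so the effect of replacing its carboxylic acid with an ester also remains open.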